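The source may hold more compounds than are shown below. What is called first, only, known or untested is meant among the compounds shown, and "the series" means these compounds.

Compound 1 `O=C(Nc1cccc(-c2ccsc2)c1)C(Cl)Cl` carries a thiophen-3-yl group on the shared core, and in a functional assay on A549 cells (Homo sapiens) for cytotoxicity, read by MTT assay, with a stated time of 68 h (on this read-out lower numbers stand for stronger inhibition and higher numbers for weaker inhibition), compound 1 gives > 50000 nM, which is a limit and not a number. Compound 2 `O=C(Nc1cccc(-c2ccc(-c3ccccc3)cc2)c1)C(Cl)Cl` gives > 50000 nM, also a limit. Compound 3 `O=C(Nc1cccc(-c2cccc(C(F)(F)F)c2)c1)C(Cl)Cl` gives a true number, 18500 nM. Compound 1 therefore stands at the limit of > 50000 nM in this assay, at which 2 of the 3 values shown sit. Compound 4 `O=C(Nc1cccc(-c2ccoc2)c1)C(Cl)Cl` has furan-3-yl in place of thiophen-3-yl on an aromatic carbon. Within the data shown here, no measured pair shows this swap, so no shift beyond the usual scatter is expected in this assay, and compound 4 should remain weak. The expected change is an at least 1.1-fold lower number from compound 1 to compound 4 (0.04 log units; that floor lies within the scatter). For compound 4 the estimated half-maximal inhibitory concentration is 45000 nM, with an expected range from 18000 nM to 70000 nM.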

Compound 4, half-maximal inhibitory concentration: 8480 nM
The estimate for compound 4 lay 5.3-fold (0.72 log units) above the measured number, and the stated range ends above it.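

In this assay, the step at this position shows that a single hetero atom in the ring can matter: furan-3-yl in place of thiophen-3-yl gives an at least 5.8-fold lower number from compound 1 to compound 4 (0.77 log units; beyond the scatter). Among these compounds, the two rings match in size and in the counts of donors and acceptors, and no earlier pair isolated such a small swap. The true size of the step remains unknown because compound 1 has a limit and not a number: the limit of > 50000 nM in this assay, at which 2 of the 4 values shown sit.

As far as these compounds go, whether a pyridine ring or a simple amine at this position would lower the number further stays open. So does whether this swap would have the same effect with a different group in place of the dichloroacetyl part.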